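The source may hold more compounds than are shown below. What is called first, only, known or untested is meant among the compounds shown, and "the series" means these compounds.

In an in vitro functional assay on HEK ts201 cells for antagonist activity at Neuronal acetylcholine receptor; alpha4/beta2 (Homo sapiens), read by fluorescence and calcium flux (a lower number here means a stronger inhibitor, a higher number a weaker inhibitor), compound 2 `O=C(OCC1CCCN(CCCc2ccccc2)C1)c1ccccc1-n1cc(-c2ccccc2)nn1` gives 2820 nM. Among the compounds with a single number, compound 2 has the lowest; compound 3 `c1ccc(CCCN2CCCC(COCc3ccccc3-c3ccccc3)C2)cc1` gives 12600 nM in this assay, a gap beyond the usual scatter. Compound 1 `O=C(OCC1CCCN(CCCc2ccccc2)C1)c1ccccc1-c1ccccc1` was run twice in this assay and gave 13500 nM; 13500 nM (2 entries) both times. Compound 4 `O=C(OCC1CCCN(CCCc2ccccc2)C1)c1ccccc1N1C(=O)c2ccccc2C1=O` has not yet been measured. It differs from compound 2 by a group of 11 heavy atoms (8 carbon, 1 nitrogen, 2 oxygen; one five-membered non-aromatic ring with 1 hetero atom, one six-membered aromatic ring of carbon only) in place of a group of 11 heavy atoms (8 carbon, 3 nitrogen; one five-membered aromatic ring with 3 hetero atoms, one six-membered aromatic ring of carbon only), on an aromatic carbon. Going by the values given here, no pair of measured compounds shares this change, so the direction is open; a modest rise in the number, toward weaker inhibition, is expected, with the step from compound 2 to compound 4 estimated at a 2.1-fold higher number from compound 2 to compound 4 (0.33 log units; beyond the scatter). Compound 4 is therefore expected to give about 6000 nM in this assay, within a range from 1500 nM to 25000 nM.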

Compound 4, half-maximal inhibitory concentration: 5010 nM
Beside the measured number, compound 4's estimate is 1.2-fold (0.08 log units) above it, and the stated range covers the measured number.
By their numbers in this assay, from the lowest: compounds 2 and 4 (each within the scatter of the next); then compound 3.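

In this assay, replacing the 4-phenyl-1H-1,2,3-triazol-1-yl group with the non-aromatic ring group on this aromatic carbon gives a 1.8-fold higher number from compound 2 to compound 4 (0.25 log units; within the scatter), so the two groups cannot be told apart here. For this pair, then, a five-membered aromatic ring with 3 hetero atoms is not needed to stay at this level. Nothing measured here explains why the two groups read alike. Going by these compounds, what a much smaller group on this carbon, such as an amine or a carboxylic acid, would give stays open. So does how much this level depends on the rest of the shared core.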